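This account rests on a few compounds, and the source may have more. Where it says the series, first, only, none or still open, it means among the compounds named here.

Measured so far in an assay on HEK293 cells for positive allosteric modulation of metabotropic glutamate receptor 2 (Rattus norvegicus), read by thallium flux, with a stated time of 2.5 min; a lower number here means that less compound is needed, a higher number that more compound is needed for the effect:
compound 1, `CCC(=O)c1ccc(OCCCCOc2ccc(F)c(C(=O)O)c2)c(C)c1O`: 124 nM
compound 2, `Cc1c(OCCCCOc2ccc(F)c(C(=O)O)c2)ccc(C(=O)CC2CCCC2)c1O`: 699 nM
compound 3, `CC(=O)c1ccc(OCCCCOc2ccc(F)c(C(=O)O)c2)c(C)c1O`: 259 nM

Compound 3 stands second highest of the three numbers; its nearest neighbour is compound 1 with a 2.1-fold higher number from compound 1 to compound 3 (0.32 log units; beyond the scatter), and compound 2 lies further away with a 2.7-fold lower number from compound 2 to compound 3 (0.43 log units; beyond the scatter).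

Compound 4 is `Cc1c(OCCCCOc2ccc(F)c(C(=O)O)c2)ccc(C(=O)C(C)C)c1O`, not yet measured in this assay. The change from compound 3 is isopropyl in place of methyl on a carbonyl carbon.

Among the compounds with values here, two measured steps bear on this change, as all three vary the group on the carbonyl carbon. Adding one carbon there, a 2.1-fold higher number from compound 1 to compound 3 (0.32 log units; beyond the scatter) read backwards, lowered the number, while the far larger cyclopentyl addition, a 5.6-fold higher number from compound 1 to compound 2 (0.75 log units; beyond the scatter), raised it. Isopropyl falls between these in size, so the expectation for compound 4 is a number close to compound 3, or slightly lower, with a step of a 1.4-fold lower number from compound 3 to compound 4 (0.13 log units; within the scatter) that may not clear the scatter. Compound 4 is therefore estimated at 190 nM, between 70 nM and 500 nM.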

Compound 4, half-maximal effective concentration: 171 nM
Compound 4: middle estimate off by 1.1-fold (0.05 log units), on the high side, within the range that was stated.
By their numbers in this assay, from the lowest: compounds 1, 4 and 3 (each within the scatter of the next, the first and the last beyond it); then compound 2.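

In this assay, branching on the carbonyl side chain produces no readable change: a 1.4-fold higher number from compound 1 to compound 4 (0.14 log units; within the scatter) and a 1.5-fold lower number from compound 3 to compound 4 (0.18 log units; within the scatter) both stay within the scatter, so isopropyl is tolerated at this carbonyl carbon. The loss seen with cyclopentylmethyl is not shared by the smaller branched group, with a 4.1-fold lower number from compound 2 to compound 4 (0.61 log units; beyond the scatter) beyond the scatter, so among these four compounds only cyclopentylmethyl clearly raises the number. Nothing available here explains these differences.

Going by these compounds, it remains open whether the higher number of compound 2 goes with the ring or with the overall size of cyclopentylmethyl, which a tert-butyl, a cyclopentyl placed directly on the carbonyl carbon or a longer unbranched chain could help separate. Also open, on these data alone, is how an amine or a hydroxyl on this side chain would read.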